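This account rests on a few compounds, and the source may have more. Where it says the series, first, only, none or still open, it means among the compounds named here.

Going by the values given here, in a functional assay on VCaP cells (Homo sapiens) for antiproliferative activity, read by fluorescence and propidium iodide staining, with a stated time of 96 h (on this read-out lower numbers stand for stronger inhibition and higher numbers for weaker inhibition), two compounds have numbers so far. Compound 1 (`CC(O)(CSc1ccccc1C(F)(F)F)C(=O)Nc1cc(C(F)(F)F)cc(C(F)(F)F)c1`) gives 3840 nM. Compound 2 (`CC(O)(COc1cc(C(F)(F)F)cc(C(F)(F)F)c1)C(=O)Nc1ccc(C#N)cc1C(F)(F)F`) gives 4770 nM, which lies within the usual scatter of compound 1, and the two values cannot be told apart. Among the compounds with values here, compound 2 therefore stands level with the only other measured compound, and neither can be called the stronger.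

Compound 3 (`CC(O)(COc1cc(C(F)(F)F)cc(C(F)(F)F)c1)C(=O)Nc1ccc([N+](=O)[O-])cc1C(F)(F)F`) has not yet been measured. It carries nitro in place of cyano on an aromatic carbon, meta to a trifluoromethyl group and para to a large group (nitro in place of cyano on an aromatic carbon). Within the data shown here, no measured pair of compounds differing in one place is available to show what such a change does in this assay. The nearest reference is compound 2 at 4770 nM, and no step beyond the scatter is expected from it, in either direction. The estimated change is a 1.2-fold lower number from compound 2 to compound 3 (0.08 log units; within the scatter), which is expected to stay within the scatter. For compound 3 the estimated half-maximal inhibitory concentration is 4000 nM, with an expected range from 1500 nM to 10000 nM.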

Compound 3, half-maximal inhibitory concentration: 23700 nM
Compound 3: the middle estimate sits 5.9-fold (0.77 log units) below what was measured, and the stated range ends below it.
By their numbers in this assay, from the lowest: compounds 1 and 2 (each within the scatter of the next); then compound 3.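

In this assay, putting nitro in place of cyano on this aromatic carbon, meta to a trifluoromethyl group and para to a large group, gives a 5.0-fold higher number from compound 2 to compound 3 (0.70 log units; beyond the scatter). This is the first change in a single place among the compounds shown, and it indicates that this position is not indifferent to which of the two groups it carries: with all else held constant, cyano goes with the stronger inhibition and nitro with the weaker. No measurement at hand on these compounds accounts for the size or direction of this step.

Going by these compounds, it remains open how an amine, a carboxylic acid or a plain hydrogen on this same carbon would stand against the cyano of compound 2 and the nitro of compound 3. On these data alone, it is also open whether exchanging cyano for nitro would give a step of similar size if another part of compound 2 were changed, for instance with a sulfur atom in place of the linking oxygen.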